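One Extra Methyl on a Chain: What Compound 4 May Give

The source may report more compounds than this note shows. Statements on the series, on what has been measured and on what is new or still open speak of the compounds shown alone.

Measured so far:
Compound 1, `CCCCCCCn1c(N2CCN(C)CC2)nc2ccccc21`, gives 150 nM in a functional assay on ileum for inhibition of histamine H1 receptor (Cavia porcellus); a higher number here means a weaker inhibitor, a lower number a stronger inhibitor.
Compound 2, `CCCCCCn1c(N2CCN(C)CC2)nc2ccccc21`, gives 26 nM in this assay.
Compound 3, `CCCCN1CCN(c2nc3ccccc3n2CCOCC)CC1`, gives 15 nM in this assay.

Compounds 1 and 2 share one core and differ only by methyl in place of hydrogen on a saturated chain carbon, six bonds along the chain from an aromatic nitrogen. That change produced a 5.8-fold higher number from compound 2 to compound 1 (0.76 log units; beyond the scatter), a weakening. Compound 3 has a different core; how the two cores differ is not broken down here. In this assay compound 3 and compound 2 lie within the scatter of each other, while compound 1 is weaker than both.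

Compound 4, `CCCCCN1CCN(c2nc3ccccc3n2CCOCC)CC1`, differs from compound 3 by methyl in place of hydrogen on a saturated chain carbon, four bonds along the chain from an amine nitrogen in a ring. For the measured compounds named here, this is the same kind of change as the one from compound 2 to compound 1, but the place is not the same: there it sat six bonds along the chain from an aromatic nitrogen, here four bonds along the chain from an amine nitrogen in a ring. The earlier step is therefore only a rough guide, and a single precedent is thin evidence. The step from compound 3 to compound 4 is expected to be a weakening of about a 2.7-fold higher number from compound 3 to compound 4 (0.43 log units; beyond the scatter), smaller than the earlier one. Compound 4 is expected to give 40 nM, within a range from 15 nM to 120 nM.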

Compound 4, half-maximal inhibitory concentration: 30 nM
Estimate against measurement, compound 4: 1.3-fold (0.12 log units) above; measured number inside the range.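

The extra methyl gives, in this assay, a 2.0-fold higher number from compound 3 to compound 4 (0.30 log units; within the scatter), so on this core the change cannot be told apart from the ordinary spread of repeated measurements. Set beside the earlier step, the same change does not carry over at the same size from one core to the other: the same change on two cores in this assay, a 5.8-fold higher number (0.76 log units; beyond the scatter) from compound 2 to compound 1 and a 2.0-fold higher number (0.30 log units; within the scatter) from compound 3 to compound 4, 2.9-fold (0.46 log units) apart, beyond the scatter of two such steps

For the compounds shown here, this rests on only two pairs, and the methyl sits at a different place in each, six bonds along the chain from an aromatic nitrogen in one and four bonds along the chain from an amine nitrogen in a ring in the other, so it does not show whether the core or the place lies behind the gap, nor how the change would behave on a further core.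

The compounds shown leave open whether a longer chain, or a chain carrying a hydroxyl group or a carboxylic acid, would follow either step. Also open, from the compounds shown here alone, is whether the two steps would come closer if the change stood at the same place on both cores.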